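The source may report more compounds than this note shows. Statements on the series, on what has been measured and on what is new or still open speak of the compounds shown alone.

Compound 3, `COc1ccc(-c2cnc(NC(=O)c3cnc[nH]3)n2C)cc1`, is the starting point of this step. In a toxicity assay on THP-1 cells (Homo sapiens) for inhibition (on this read-out lower numbers stand for higher toxicity in this test and higher numbers for lower toxicity in this test), compound 3 gives only a limit of the assay, > 100000 nM. The two other measured compounds end at the same limit. Compound 1, `COc1ccc(-c2cnc(NC(=O)c3cccc(OC)c3)n2C)cc1`, in this assay gives a limit, > 100000 nM. Compound 2, `COc1ccc(-c2cnc(NC(=O)c3cccc(Br)c3)n2C)cc1`, in this assay gives a limit, > 100000 nM. The steps among them, a step that the two limits leave unreadable from compound 1 to compound 2, a step that the two limits leave unreadable from compound 1 to compound 3 and a step that the two limits leave unreadable from compound 2 to compound 3, have no readable size, which the limit of > 100000 nM in this assay, at which 3 of the 3 values shown sit, sums up. Compound 4 is `COc1ccc(-c2cnc(NC(=O)c3cccc(Cl)c3)n2C)cc1`. It differs from compound 3 in one place: 3-chlorophenyl in place of 1H-imidazol-5-yl on a carbonyl carbon. The step from compound 2 to compound 3 changes the group on the carbonyl carbon in the reverse sense, yet its size is hidden by the limits, so nothing measured says how compound 4 should move in this assay. The step that the limit leaves unreadable from compound 3 to compound 4 is expected to have no readable size. Compound 4 is estimated to sit at the limit again, around 150000 nM, between 30000 nM and 600000 nM.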

Compound 4, half-maximal cytotoxic concentration: > 28000 nM
Compound 4 ended at the assay's limit (the forecaster's own chance of this, stated with the estimate: 80%); the middle value does not contradict the limit.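

In this assay compound 4 gives > 28000 nM, a limit of the assay. Its steps from compound 1, compound 2 and compound 3 all join two limits and cannot be read. The compounds shown leave open whether changing the group on the carbonyl carbon alters this read-out at all, as none of the four gives a value that is not a limit.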